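Amide variation on a pyrazole HMG-CoA reductase inhibitor series

A few compounds are considered here, and "the series" means these few. Any claim that something is new, unique, unknown or untested is made for them only; others in the source may bear on it.

Measured compounds:
compound 1, `CC(C)c1c(C(=O)N2CCC[C@H](c3ccccc3)C2)nn(-c2ccc(F)cc2)c1CC[C@@H](O)C[C@@H](O)CC(=O)O`, 2.1 nM
compound 2, `CC(C)c1c(C(=O)N(C)Cc2cccc(F)c2)nn(-c2ccc(F)cc2)c1CC[C@@H](O)C[C@@H](O)CC(=O)O`, 4.1 nM
compound 3, `Cc1ccc(CN(C)C(=O)c2nn(-c3ccc(F)cc3)c(OC[C@@H](O)C[C@@H](O)CC(=O)O)c2C(C)C)cc1`, 37 nM

In an assay on microsomes from liver for inhibition of 3-hydroxy-3-methylglutaryl-coenzyme A reductase (Rattus norvegicus) (a higher number here means a weaker inhibitor, a lower number a stronger inhibitor), compound 3 gives the highest number of the three measured compounds; the gap to compound 2 and the wider gap to compound 1 are both beyond the usual scatter. Compound 4, `COc1cccc(CNC(=O)c2nn(-c3ccc(F)cc3)c(OC[C@@H](O)C[C@@H](O)CC(=O)O)c2C(C)C)c1`, keeps the core of compound 3 and changes only the amide end: (3-methoxybenzyl)amino in place of methyl(4-methylbenzyl)amino on a carbonyl carbon. Within the data shown here, the one measured step that concerns the amide, a 2.0-fold higher number from compound 1 to compound 2 (0.29 log units; within the scatter), lies within the scatter, but it was made on the core of compound 1, not on the ether-linked core shared by compound 3 and compound 4, so it bears on the present step only loosely. Among the measured compounds shown here, no step on that core has been measured. The expectation is therefore a step of modest size in this assay, a 1.1-fold higher number from compound 3 to compound 4 (0.03 log units; within the scatter), with the direction uncertain. Compound 4 is estimated at 40 nM, with a range from 12 nM to 130 nM.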

Compound 4, half-maximal inhibitory concentration: 16 nM
Estimate against measurement, compound 4: 2.5-fold (0.40 log units) above, within the range that was stated.
By their numbers in this assay, from the lowest: compounds 1 and 2 (each within the scatter of the next); then compound 4; then compound 3.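

In this assay, among these compounds, the amide end on the ether-linked core is not silent: a 2.3-fold lower number from compound 3 to compound 4 (0.36 log units; beyond the scatter), a modest step but one beyond the scatter, whereas the only amide step available earlier, a 2.0-fold higher number from compound 1 to compound 2 (0.29 log units; within the scatter), on the core of compound 1, stayed within it. The change is a combined one, as (3-methoxybenzyl)amino brings a hydrogen-bond donor and an oxygen that methyl(4-methylbenzyl)amino lacks, and this single step cannot divide its size among those differences. Nothing measured here gives a reason for the step.

On these data alone, it remains open whether the amide hydrogen or the methoxy group carries the step, which methyl(3-methoxybenzyl)amino on the same carbonyl carbon would separate. As far as these compounds go, how this core responds to a hydroxyl on the benzyl ring, or to a longer chain in place of the benzyl group, also remains open.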